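Replacing one ring with 6-fluoropyridin-3-yl in compound 4

A few compounds are considered here, and "the series" means these few. Any claim that something is new, unique, unknown or untested is made for them only; others in the source may bear on it.

- Compound 1 `O=C(Nc1cccc(F)c1)c1cc(=O)[nH]c2cc(F)ccc12`: > 20000 nM (a limit)
- Compound 2 `Nc1ccc(-c2ccc3c(C(=O)Nc4cccc(F)c4)cc(=O)[nH]c3c2)cc1`: > 20000 nM (a limit)
- Compound 3 `O=C(Nc1cccc(F)c1)c1cc(=O)[nH]c2cc(C3=CCOCC3)ccc12`: 12100 nM

Among the measured compounds shown here, in a functional assay on KYSE-410 cells (Homo sapiens) for antiproliferative activity, read by MTT assay, with a stated time of 72 h (a lower number here means a stronger inhibitor, a higher number a weaker inhibitor), compound 3 gives 12100 nM, the only true number so far. The other two results are only limits of the assay, as the limit of > 20000 nM in this assay, at which 2 of the 3 values shown sit, records.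

Compound 4 `O=C(Nc1cccc(F)c1)c1cc(=O)[nH]c2cc(-c3ccc(F)nc3)ccc12` changes the group on compound 3: a group of 7 heavy atoms (5 carbon, 1 nitrogen, 1 fluorine; one six-membered aromatic ring with 1 hetero atom) in place of a group of 6 heavy atoms (5 carbon, 1 oxygen; one six-membered non-aromatic ring with 1 hetero atom), on an aromatic carbon. The entering group is 6-fluoropyridin-3-yl, on an aromatic carbon.

For the measured compounds named here, two measured steps bear on this. Compound 2 also carries a six-membered aromatic ring at this place, so the closest guide is an at least 1.6-fold lower number from compound 2 to compound 3 (0.21 log units; that floor lies within the scatter). The other guide is an at least 1.6-fold lower number from compound 1 to compound 3 (0.21 log units; that floor lies within the scatter). Both steps are only floors within the scatter, and a step that the two limits leave unreadable from compound 1 to compound 2 adds no size. Neither therefore supports a clear shift in either direction in this assay.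

No change beyond the scatter is expected, and the estimate is a 1.2-fold higher number from compound 3 to compound 4 (0.06 log units; within the scatter). The expected value for compound 4 is 14000 nM, with an estimated range from 5000 nM to 30000 nM.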

Compound 4, half-maximal inhibitory concentration: > 20000 nM
Compound 4 was reported as a limit (the forecaster's own chance of this, stated with the estimate: 40%); middle value at least 1.4-fold (0.15 log units) away from the limit.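

Among the compounds shown here, the change to 6-fluoropyridin-3-yl at this position gives an at least 1.6-fold higher number from compound 3 to compound 4 (0.21 log units; that floor lies within the scatter), so the data do not establish a real loss, and compound 3 remains the only compound with a true number. Compound 4 is a limit in this assay, and a six-membered aromatic ring at this position, in compound 2 and now in compound 4, has so far given only a limit: the limit of > 20000 nM in this assay, at which 3 of the 4 values shown sit. The steps from compound 1 and from compound 2 to compound 4 have limits at both ends and cannot be read.

From the compounds shown here alone, the true distance between compound 3 and compound 4 stays open, as does the part played by the ring oxygen or the double bond of compound 3. The compounds shown also leave open how a morpholine ring or a carboxylic acid would behave at this position.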